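Replacing the pyridin-2-yl group of compound 3

This account rests on a few compounds, and the source may have more. Where it says the series, first, only, none or still open, it means among the compounds named here.

In a functional assay on K562 cells (Homo sapiens) for inhibition, read by trypan blue exclusion, with a stated time of 72 h (on this read-out lower numbers stand for stronger inhibition and higher numbers for weaker inhibition), compound 3 (`Cn1c(=O)c(S(=O)(=O)c2ccc(F)cc2F)cc2cnc(Nc3ccccn3)nc21`) gives 35000 nM and is the weakest of the three measured compounds. On the same core, compound 1 (`Cn1c(=O)c(S(=O)(=O)c2ccc(F)cc2F)cc2cnc(Nc3ccc4[nH]c(C(=O)O)cc4c3)nc21`) gives 10000 nM and compound 2 (`Cn1c(=O)c(S(=O)(=O)c2ccc(F)cc2F)cc2cnc(Nc3ccc4sccc4c3)nc21`) gives 500 nM in the same read-out.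

Among the compounds with values here, compound 4 (`Cn1c(=O)c(S(=O)(=O)c2ccc(F)cc2F)cc2cnc(Nc3ccc4c(c3)C(=O)C(=O)N4)nc21`) keeps the shared core and differs by a group of 11 heavy atoms (8 carbon, 1 nitrogen, 2 oxygen; one five-membered non-aromatic ring with 1 hetero atom, one six-membered aromatic ring of carbon only) in place of a group of 6 heavy atoms (5 carbon, 1 nitrogen; one six-membered aromatic ring with 1 hetero atom), on a nitrogen on an aromatic ring as its single change.

Two measured steps end on the pyridin-2-yl group: the modest 3.5-fold higher number from compound 1 to compound 3 (0.54 log units; beyond the scatter) and the large 70-fold higher number from compound 2 to compound 3 (1.85 log units; beyond the scatter) on the same nitrogen. Both compound 1 and compound 2 carry a larger group there and stand lower than compound 3. The two larger groups also lie far apart, with a 20-fold lower number from compound 1 to compound 2 (1.30 log units; beyond the scatter) as a large step, so size alone gives only a loose guide.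

A lower number is therefore expected, with a 12-fold lower number from compound 3 to compound 4 (1.07 log units; beyond the scatter) as the estimated step in this assay and a landing place between the two larger groups. The estimate for compound 4 is 3000 nM (expected range 600 nM to 15000 nM).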

Compound 4, half-maximal inhibitory concentration: 30000 nM
Estimate against measurement, compound 4: 10-fold (1.00 log units) below; measured number outside the range, above it.
By their numbers in this assay, from the lowest: compound 2; then compound 1; then compounds 4 and 3 (each within the scatter of the next).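

In this assay the entering group, despite its extra ring and larger heavy-atom count, gives a 1.2-fold lower number from compound 3 to compound 4 (0.07 log units; within the scatter) and so cannot be told apart from pyridin-2-yl, which makes compound 4 the exception to the earlier picture of larger groups standing lower than compound 3. The same group gives a 60-fold higher number from compound 2 to compound 4 (1.78 log units; beyond the scatter) against 1-benzothiophen-5-yl and a 3.0-fold higher number from compound 1 to compound 4 (0.48 log units; beyond the scatter) against 2-carboxy-1H-indol-5-yl, so at this nitrogen three groups that each hold one five-membered and one six-membered ring are spread widely, and ring count alone does not set the number. Nothing available bears on why this is so.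

Still open, as far as these compounds go, is where a plain phenyl or an unsubstituted 1H-indol-5-yl on this nitrogen would fall relative to compound 2 and compound 4. Such groups would help show which atoms of the larger groups go with the differences seen.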